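A Second Chloro Group on the Core of Compound 3

A few compounds are considered here, and "the series" means these few. Any claim that something is new, unique, unknown or untested is made for them only; others in the source may bear on it.

Compound 1 `ClCc1cccc(Cn2cnc3c(Cl)ncnc32)c1` and compound 2 `ClCc1cccc(Cn2cnc3c(Cl)nc(Cl)nc32)c1` share one core. In a functional assay on HOP-92 cells (Homo sapiens) for cytotoxicity, read by sulforhodamine B assay, with a stated time of 48 h (on this read-out higher numbers stand for weaker inhibition of growth and lower numbers for stronger inhibition of growth), compound 1 gives 6160 nM and compound 2 gives 3630 nM. Compound 2 arises from compound 1 through (chloro in place of hydrogen on an aromatic carbon), and this step gave a 1.7-fold lower number from compound 1 to compound 2 (0.23 log units; within the scatter). Compound 3 `ClCc1ccccc1Cn1cnc2ncnc(Cl)c21` is built from the same atoms as compound 1, joined differently; the difference between the two cores is not broken down here. In this assay compound 3 gives 12900 nM, the highest of the three numbers. Compound 4 `ClCc1ccccc1Cn1cnc2nc(Cl)nc(Cl)c21` differs from compound 3 by chloro in place of hydrogen on an aromatic carbon, the same change, at the same place, as from compound 1 to compound 2. Because the earlier step was a 1.7-fold lower number from compound 1 to compound 2 (0.23 log units; within the scatter), the step from compound 3 to compound 4 is expected to be a 1.7-fold lower number from compound 3 to compound 4 (0.24 log units; within the scatter). Compound 4 is thus estimated at 7500 nM, with a range from 3800 nM to 15000 nM.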

Compound 4, concentration for total growth inhibition: 2810 nM
Estimate against measurement, compound 4: 2.7-fold (0.43 log units) above; the whole stated range lies above it.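

In this assay, chloro in place of hydrogen on an aromatic carbon, between two ring nitrogen atoms, gave a 4.6-fold lower number from compound 3 to compound 4 (0.66 log units; beyond the scatter). The size of this step therefore did not carry over from the core of compound 1 to the core of compound 3: the same change on two cores in this assay, a 1.7-fold lower number (0.23 log units; within the scatter) from compound 1 to compound 2 and a 4.6-fold lower number (0.66 log units; beyond the scatter) from compound 3 to compound 4, 2.7-fold (0.43 log units) apart, beyond the scatter of two such steps These two pairs do not show why the steps differ, and they give no rule for predicting the step on any other core in the series.

Only chloro is shown at this place, so the effect of an amine or a methoxy group there remains open. Also open, as far as these compounds go, is whether replacing the chloromethyl group, which all four compounds carry, would alter the size of the step.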